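This account rests on a few compounds, and the source may have more. Where it says the series, first, only, none or still open, it means among the compounds named here.

Measured in a functional assay on A-375 cells (Homo sapiens) for antiproliferative activity, read by CCK-8 assay, with a stated time of 72 h; on this read-out lower numbers stand for stronger inhibition and higher numbers for weaker inhibition:
- compound 1 `CCc1ccc(SCc2ccc(/C=C/C(=O)Nc3ccccc3N)cc2)cc1`: "not determined" (no result reported)
- compound 2 `COc1ccc(SCc2ccc(C(=O)Nc3ccccc3N)cc2)cc1`: 3010 nM

Going by the values given here, compound 2, at 3010 nM, gives the only number available in this assay, so it cannot yet be ranked as strong or weak against a related compound. Compound 1 also carries an ethyl group, but with "not determined" (no result reported) it offers no numerical comparison.

The next compound to be tested is compound 3 `CCc1ccc(SCc2ccc(C(=O)Nc3ccccc3N)cc2)cc1`. It keeps the core of compound 2 and makes one change, with ethyl in place of methoxy on an aromatic carbon.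

Among the compounds with values here, no measured pair here shows what this exchange does, so the expectation has little to rest on. The best available anchor is compound 2 at 3010 nM, and a sensible default is that this small exchange causes no large shift. The expected change, a 1.1-fold lower number from compound 2 to compound 3 (0.03 log units; within the scatter), is therefore small, with no shift beyond the usual scatter and no confident direction.

For compound 3 the estimated value is 2800 nM, with an expected range from 1000 nM to 8000 nM.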

Compound 3, half-maximal inhibitory concentration: 2420 nM
The estimate for compound 3 lay 1.2-fold (0.06 log units) above the measured number, and the stated range covers the measured number.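

In this assay, replacing methoxy with ethyl on this aromatic carbon, para to a large group, gives a 1.2-fold lower number from compound 2 to compound 3 (0.09 log units; within the scatter), so this exchange does not separate the 4-methoxyphenyl and 4-ethylphenyl forms on this read-out. Going by these compounds alone, this is the first measured pair at this position, and it shows that a group with one hydrogen-bond acceptor and a group with none, each with 2 heavy atoms, give values within the usual scatter of each other. No available evidence explains this result, so it describes what was observed without giving a cause.

A single pair cannot show how far this similarity extends, and an amine, a carboxylic acid or a longer chain such as butyl at the same position could give a quite different value. Compound 1 also carries the ethyl group, but its "not determined" (no result reported) gives no number, so the compounds shown leave open how ethyl behaves when the rest of the molecule differs from compound 3.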